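The source may report more compounds than this note shows. Statements on the series, on what has been measured and on what is new or still open speak of the compounds shown alone.

Among the measured compounds shown here, compound 2 `CN(C)CCn1cnnc1-c1cc(Oc2ccc(NC(=O)N/N=C/c3ccc(O)cc3)cc2F)ccn1` gives the lower of the two numbers so far in a functional assay on MKN-45 cells (Homo sapiens) for cytotoxicity, read by MTT assay, with a stated time of 72 h (on this read-out lower numbers stand for stronger inhibition and higher numbers for weaker inhibition), at 820 nM. Compound 1 `CN(C)CCn1cnnc1-c1cc(Oc2ccc(NC(=O)N/N=C/c3ccccc3)cc2F)ccn1`, which carries a plain phenyl on the same carbon, gives 2730 nM in this assay, and the change from it to compound 2 is a 3.3-fold lower number from compound 1 to compound 2 (0.52 log units; beyond the scatter). Compound 3 `CN(C)CCn1cnnc1-c1cc(Oc2ccc(NC(=O)N/N=C/c3cccc(O)c3)cc2F)ccn1` has not yet been measured. It differs from compound 2 in that (3-hydroxyphenyl in place of 4-hydroxyphenyl on a carbon with a double bond to nitrogen). For the measured compounds named here, the only measured step that bears on this change is the one from compound 1 to compound 2, which shows that placing a hydroxy on that ring matters to the read-out, but nothing measured tells how the ring position of the hydroxy matters. Compound 3 is therefore expected to land near compound 2 or somewhat weaker, a step of a 1.7-fold higher number from compound 2 to compound 3 (0.23 log units; within the scatter), with an estimate of 1400 nM in this assay and a range from 500 nM to 4000 nM.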

Compound 3, half-maximal inhibitory concentration: 1370 nM
The estimate for compound 3 lay 1.0-fold (0.01 log units) above the measured number; low and high end bracket the measured number.
By their numbers in this assay, from the lowest: compounds 2, 3 and 1 (each within the scatter of the next, the first and the last beyond it).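

Moving the hydroxy on the ring, with 3-hydroxyphenyl in place of 4-hydroxyphenyl, gives a 1.7-fold higher number from compound 2 to compound 3 (0.22 log units; within the scatter) in this assay, so these two placements cannot be told apart here. The other new step, a 2.0-fold lower number from compound 1 to compound 3 (0.30 log units; within the scatter), is just as unresolved: compound 3 cannot be separated from either of the others, even though compound 1 and compound 2 do differ clearly from each other. No measurement shown here offers an explanation for this pattern.

The compounds shown leave open whether the hydroxy itself matters or whether another group on this ring, such as a methoxy, an amine or a carboxylic acid, would serve as well. They also leave open what a ring carrying two hydroxy groups would give in this read-out.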